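This account rests on a few compounds, and the source may have more. Where it says the series, first, only, none or still open, it means among the compounds named here.

Compound 1: `COC(=O)c1ccc(NCc2cncn2Cc2ccccc2C(C)(C)C)cc1-c1ccccc1` — "not determined" (no result reported)
Compound 2: `Nc1cc(-c2ccccc2)ccc1Cn1cncc1CNc1ccc(Cl)c(-c2ccccc2)c1` — > 1000 nM
Compound 3: `CC(C)c1ccc(Cn2cncc2CNc2ccc(-c3nc4ccccc4s3)c(-c3ccccc3)c2)cc1` — > 1000 nM

All three compounds were tested in a toxicity assay on NIH3T3 cells (Mus musculus) for cytotoxicity, read by resazurin assay; a higher number here means that more compound is needed for the effect, a lower number that less compound is needed. For compound 1 the outcome is "not determined" (no result reported), so no number stands behind it. Compound 2 reached only a limit of the assay, > 1000 nM, which is not a measured number. Compound 3 likewise reached only a limit, > 1000 nM. Where compound 1 stands therefore cannot be read from a single value; the two further values shown sit at the limit of > 1000 nM in this assay, at which 2 of the 3 values shown sit, and no step between two measured compounds is available.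

The piece follows the step from compound 1 to compound 4, `COC(=O)c1ccc(NCc2cncn2Cc2ccccc2N)cc1-c1ccccc1`. The change is amino in place of tert-butyl on an aromatic carbon: amino in place of tert-butyl, on an aromatic carbon of a six-membered aromatic ring of carbon only, ortho to a large group.

Within the data shown here, with no measured step to lean on, the expectation for this assay rests only on the two limits of compound 2 and compound 3, which give no direction. No step beyond the scatter is expected in either direction. For compound 4 an estimated value of 3000 nM is expected, within a range from 1000 nM to 10000 nM, with a fair chance that the assay again reports only a limit.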

Compound 4, half-maximal effective concentration: 25000 nM
The estimate for compound 4 lay 8.3-fold (0.92 log units) below the measured number; the measured number lies above the stated range.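

In this assay, among these compounds, compound 4 gives 25000 nM, but compound 1 has no number to set against it, so no step from compound 1 to compound 4 can be read. The compounds shown leave open whether amino in place of tert-butyl changes the value in this assay, and in which direction.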